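This account rests on a few compounds, and the source may have more. Where it says the series, first, only, none or still open, it means among the compounds named here.

Compound 1, `COc1ccc(-c2cc(/C=C/C(=O)c3ccc(OC)c(OC)c3)[nH]n2)cc1`, gives 98% in a functional assay on CAKI-1 cells (Homo sapiens) for cytotoxicity, read by sulforhodamine B assay, with a stated time of 48 h, tested at 0.01 uM; on this read-out higher numbers stand for a weaker effect at the one concentration tested and lower numbers for a stronger effect.
Compound 2, `COc1ccc(C(=O)/C=C/c2cc(-c3cc(OC)c(OC)c(OC)c3)n[nH]2)cc1`, gives 95% in this assay.
Compound 3, `COc1cc(C(=O)/C=C/c2cc(-c3cc(OC)c(OC)c(OC)c3)n[nH]2)cc(OC)c1OC`, gives 91% in this assay.

All three measured compounds share a core and differ only in the methoxy-bearing rings at either end. On the numbers shown, compound 2 sits in the middle of the three, with compound 1 the nearest and compound 3 the furthest from it; both of those gaps lie within the usual scatter of this assay, so the three compounds cannot be told apart here, and all of them show only a weak effect at the single concentration tested.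

The unmeasured compound 4, `COc1cc(-c2cc(/C=C/C(=O)c3ccc(F)c(F)c3)[nH]n2)cc(OC)c1OC`, is reached from compound 2 by one change: 3,4-difluorophenyl in place of 4-methoxyphenyl on a carbonyl carbon. Within the data shown here, no step between two measured compounds is available to show how such a change affects this assay, since the measured compounds vary only in the number of methoxy groups, not in a fluorine-for-methoxy swap. With every measured value close to the top of the scale, the expected step is none beyond the scatter. Compound 4 is therefore estimated at 93%, in a range from 80% to 100%, which as a step means a number 2 percentage points lower from compound 2 to compound 4 (within the scatter).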

Compound 4, a percentage reported as activity, at one concentration (the size of the read-out at that concentration, not a potency): 95%
Beside the measured number, compound 4's estimate is 2 percentage points below it, and the stated range covers the measured number.
By their numbers in this assay, from the lowest: compounds 3, 2, 4 and 1 (each within the scatter of the next).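

In this assay, 3,4-difluorophenyl in place of 4-methoxyphenyl on a carbonyl carbon gives no change at the digits printed from compound 2 to compound 4 (within the scatter). The earlier compounds shown here carried only methoxy-bearing rings, so they could not show what happens when a ring with fluorine and no methoxy group stands at this place; here, such a ring leaves the read-out close to the top of the scale, where all the methoxy-bearing compounds also sit. Nothing measured here offers an explanation for this result, so the outcome can be recorded but not accounted for.

With only one low concentration shown and every value near the top of the scale, the compounds leave open whether this swap would make any difference at concentrations where the compounds have a clear effect. Also open, going by these compounds, is how this place responds to groups of a different kind on the carbonyl carbon, such as a ring carrying an amine or a carboxylic acid, or a longer chain instead of a ring.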